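From a Cyclohexyl Ring to a Butyl Chain

This account rests on a few compounds, and the source may have more. Where it says the series, first, only, none or still open, it means among the compounds named here.

Three compounds on a shared core have been measured in a functional assay on the whole organism (strain Sprague-Dawley) for inhibition, with Rattus norvegicus as the target; a lower number here means that less compound is needed, a higher number that more compound is needed for the effect:
Compound 1, `Fc1ccc2ncc(-c3nn[nH]n3)cc2c1`: 50 mg/kg
Compound 2, `c1cc2ncc(-c3nn[nH]n3)cc2cc1OC1CCCCC1`: 10 mg/kg
Compound 3, `c1nc2ccc(C3CCCCC3)cc2cc1-c1nn[nH]n1`: > 25 mg/kg, a limit only

Compound 3 stands apart from the other two in this assay in that its result is a limit, > 25 mg/kg, and not a number. The step of an at least 2.5-fold higher number from compound 2 to compound 3 (0.39 log units; beyond the scatter) is therefore readable only as a bound, and the step that the limit leaves unreadable from compound 1 to compound 3 cannot be sized at all; both end at the limit of > 25 mg/kg in this assay, at which 1 of the 3 values shown sits. Compound 4, `CCCCc1ccc2ncc(-c3nn[nH]n3)cc2c1`, differs from compound 3 in one place: butyl in place of cyclohexyl on an aromatic carbon. Going by the values given here, no measured step exchanges one carbon group for another of a different shape, so none bears directly on this change. The step of a 5.0-fold lower number from compound 1 to compound 2 (0.70 log units; beyond the scatter), cyclohexyloxy in place of fluoro, shows that a larger group at this position can lower the number, but it passes through neither cyclohexyl nor butyl. With compound 3 fixed only from below, the direction of the step to compound 4 cannot be set from these data, and a number near the edge of the measurable range is as likely as a limit. Compound 4 is estimated at 30 mg/kg, between 10 mg/kg and 100 mg/kg, which would mean an expected step that the limit leaves unreadable from compound 3 to compound 4.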

Compound 4, minimum effective dose: > 25 mg/kg
Compound 4 ended at the assay's limit; the forecaster's own chance of this, stated with the estimate: 50%; the middle value is on the limit's open side.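

In this assay compound 4 gives > 25 mg/kg, which is a limit of the assay and not a number. The exchange of cyclohexyloxy for butyl comes with an at least 2.5-fold higher number from compound 2 to compound 4 (0.39 log units; beyond the scatter), a bound of the same kind as an at least 2.5-fold higher number from compound 2 to compound 3 (0.39 log units; beyond the scatter), so at this place on the aromatic carbon neither the ring of cyclohexyl nor the open chain of butyl is shown to reach the number held by the cyclohexyloxy compound. The steps from compound 3 to compound 4 and from compound 1 to compound 4 cannot be read, so cyclohexyl and butyl cannot be put in any order: the limit of > 25 mg/kg in this assay, at which 2 of the 4 values shown sit.

Going by these compounds, it remains open whether butoxy, the open-chain counterpart of cyclohexyloxy, would give a number in the way compound 2 does with 10 mg/kg, which would show whether the ring matters once the oxygen link is present. Also open, on these data alone, is whether an amine linking the cyclohexyl ring to the aromatic carbon would give a number at all in this assay.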